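Fluoro to methyl on the difluoromethyl carbon

A few compounds are considered here, and "the series" means these few. Any claim that something is new, unique, unknown or untested is made for them only; others in the source may bear on it.

Measured compounds:
compound 1, `CNc1cc(Oc2ccc(NC(=O)Nc3cccc(C(F)F)c3)cc2)ncn1`: 100 nM
compound 2, `CC(C)Nc1cc(Oc2ccc(NC(=O)Nc3cccc(C(F)(F)F)c3)cc2)ncn1`: 40 nM

In an assay on isolated protein for inhibition of serine/threonine-protein kinase TNNI3K (Homo sapiens) (on this read-out lower numbers stand for stronger inhibition and higher numbers for weaker inhibition), compound 1 gives 100 nM, the higher of the two numbers at hand. Compound 2 gives 40 nM, a number that sits beyond the scatter below compound 1; the two structures differ in more than one place, so only their two values can be compared, not the effect of any single change. Compound 3, `CNc1cc(Oc2ccc(NC(=O)Nc3cccc(C(C)F)c3)cc2)ncn1`, is still to be measured in this assay. Relative to compound 1 it carries methyl in place of fluoro on a saturated chain carbon bound to an aromatic carbon and a fluorine atom. Within the data shown here, no measured pair tracks that change, so nothing here sets its size or direction. The expectation for compound 3 is a step of a 1.2-fold higher number from compound 1 to compound 3 (0.08 log units; within the scatter) that stays within the scatter, with no clear direction. Compound 3 is therefore estimated at 120 nM in this assay, with a range from 50 nM to 300 nM.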

Compound 3, half-maximal inhibitory concentration: 79 nM
Compound 3: the middle estimate sits 1.5-fold (0.18 log units) above what was measured; low and high end bracket the measured number.
By their numbers in this assay, from the lowest: compounds 2, 3 and 1 (each within the scatter of the next, the first and the last beyond it).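

In this assay, methyl in place of fluoro on a saturated chain carbon bound to an aromatic carbon and a fluorine atom gives a 1.3-fold lower number from compound 1 to compound 3 (0.10 log units; within the scatter). This first one-place comparison in the series does not tell difluoromethyl and 1-fluoroethyl apart, so the second fluorine is not needed to keep the number in this range, and the added methyl is accepted at this position. No available evidence bears on why the two groups read alike.

Going by these compounds, it remains open whether the remaining fluorine matters, which an ethyl or 1-hydroxyethyl group in the same place would test, and whether a longer chain is accepted there. Compound 2 differs from compound 1 and compound 3 in more than one place, so steps to it cannot be read.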